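The compounds below may be only part of what the source reports. "The series", "measured", "known", "first", "only" and "open" are said of these compounds alone.

Measured so far:
compound 1 `CCCCCCCCNc1nc(SCc2ccc(C(F)(F)F)cc2)nc2ccccc12` — 10500 nM
compound 2 `O=[N+]([O-])c1ccc(Nc2nc(SCc3ccc(C(F)(F)F)cc3)nc3ccccc23)cc1` — 7900 nM
compound 3 `FC(F)(F)c1ccc(CSc2nc(Nc3ccc(C(F)(F)F)cc3)c3ccccc3n2)cc1` — 7880 nM

All three share one core and differ only in the group on a nitrogen on an aromatic ring. In a functional assay on PC-3 cells (Homo sapiens) for cytotoxicity, read by MTT assay, with a stated time of 72 h (a lower number here means a stronger inhibitor, a higher number a weaker inhibitor), compound 3 gives 7880 nM; it stands nearest to compound 2 and furthest from compound 1, yet the step of a 1.0-fold lower number from compound 2 to compound 3 (0.00 log units; within the scatter) and the step of a 1.3-fold lower number from compound 1 to compound 3 (0.12 log units; within the scatter) are both within the scatter, so no ranking can be read from them.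

Compound 4 `COc1ccc(Nc2nc(SCc3ccc(C(F)(F)F)cc3)nc3ccccc23)cc1OC` carries 3,4-dimethoxyphenyl in place of 4-(trifluoromethyl)phenyl on a nitrogen on an aromatic ring. The two measured swaps at this nitrogen, from a long chain to an aryl group and from nitro to trifluoromethyl, both left the number essentially unchanged, so the step of a 1.0-fold higher number from compound 3 to compound 4 (0.01 log units; within the scatter) is expected to stay within the scatter. Compound 4 is therefore estimated at 8000 nM, in the range 3500 nM to 18000 nM.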

Compound 4, half-maximal inhibitory concentration: 14100 nM
Estimate against measurement, compound 4: 1.8-fold (0.25 log units) below; measured number inside the range.
By their numbers in this assay, from the lowest: compounds 3, 2, 1 and 4 (each within the scatter of the next).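

In this assay the 3,4-dimethoxyphenyl group brings hydrogen-bond acceptors that 4-(trifluoromethyl)phenyl lacks, yet the result is a 1.8-fold higher number from compound 3 to compound 4 (0.25 log units; within the scatter); the comparisons with the other two groups give a 1.8-fold higher number from compound 2 to compound 4 (0.25 log units; within the scatter) and a 1.3-fold higher number from compound 1 to compound 4 (0.13 log units; within the scatter). Every step among these four groups on the nitrogen therefore stays within the scatter, so this position shows no preference among an octyl chain and three substituted phenyl rings. Nothing measured here offers an explanation for this.

As far as these compounds go, whether a group carrying a carboxylic acid or an amine at this nitrogen would give a step beyond the scatter remains open.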